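This account rests on a few compounds, and the source may have more. Where it says the series, first, only, none or still open, it means among the compounds named here.

Compound 1 `CC(C)CCn1nc(-c2cncs2)c(O)c(C2=NS(=O)(=O)c3cc(NS(C)(=O)=O)ccc3N2)c1=O`: > 33000 nM, a limit
Compound 2 `CC(C)CCn1nc(-c2ccccc2)c(O)c(C2=NS(=O)(=O)c3cc(NS(C)(=O)=O)ccc3N2)c1=O`: > 1000 nM, a limit
Compound 3 `CC(C)CCn1nc(C2CCC2)c(O)c(C2=NS(=O)(=O)c3cc(NS(C)(=O)=O)ccc3N2)c1=O`: > 33000 nM, a limit
Compound 4 `CC(C)CCn1nc(CC2=CCCC2)c(O)c(C2=NS(=O)(=O)c3cc(NS(C)(=O)=O)ccc3N2)c1=O`: not yet measured

All of these compounds belong to one series tested in an ADME assay on Huh-7 cells (Homo sapiens) for cytotoxicity, with a stated time of 72 h (a lower number here means that less compound is tolerated, a higher number that more compound is tolerated), and no exact value has been obtained so far. Compound 3 stands at the limit of > 33000 nM in this assay, at which 2 of the 3 values shown sit. Compound 2 stands at the limit of > 1000 nM in this assay, at which 1 of the 3 values shown sits.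

The next step replaces cyclobutyl with (cyclopent-1-en-1-yl)methyl on an aromatic carbon of the shared core: (cyclopent-1-en-1-yl)methyl in place of cyclobutyl on an aromatic carbon. Three measured steps involve changes on this same carbon. They are a step that the two limits leave unreadable from compound 1 to compound 3, a step that the two limits leave unreadable from compound 2 to compound 3 and a step that the two limits leave unreadable from compound 1 to compound 2. None of them has a readable size or direction, so they offer no basis for predicting a shift, and no step beyond the usual scatter is expected in this assay. The new group is not tied to any measured effect, so this expectation remains loose, and another limit would be no surprise. The estimated change is a number no higher from compound 3 to compound 4 (the limit leaves the size open). The expected value for compound 4 is 33000 nM, with an estimated range from 8000 nM to 100000 nM.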

Compound 4, half-maximal cytotoxic concentration: > 33000 nM
Compound 4 gave a limit, no number (the forecaster's own chance of this, stated with the estimate: 80%); the middle value sits exactly at the limit.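

In this assay compound 4 gives only a limit, > 33000 nM, so none of its steps from compound 1, compound 2 or compound 3 can be read. The compounds shown leave open at what concentration each becomes toxic to these cells, and whether the group on this carbon changes that concentration at all.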